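Series notes: from compound 3 to compound 4

The source may hold more compounds than are shown below. What is called first, only, known or untested is meant among the compounds shown, and "the series" means these compounds.

- compound 1 `Cc1ccsc1-c1cc(-c2ccco2)cc(-c2ccccc2Cl)n1`: 29900 nM
- compound 2 `Cc1ccsc1-c1cc(-c2ccoc2)cc(-c2ccc(Cl)cc2)n1`: 20100 nM
- compound 3 `Cc1ccccc1-c1cc(-c2ccoc2)cc(-c2ccc(Cl)s2)n1`: 18500 nM

All three compounds were measured in a functional assay on DU-145 cells (Homo sapiens) for cytotoxicity, read by ELISA, with a stated time of 4 days (on this read-out lower numbers stand for stronger inhibition and higher numbers for weaker inhibition), and their values lie within the scatter of one another. Compound 3 , at 18500 nM, therefore stands level with the other two on these numbers.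

Compound 4 `Clc1cccc(-c2cc(-c3ccoc3)cc(-c3ccc(Cl)s3)n2)c1` keeps the 5-chlorothiophen-2-yl and furan-3-yl groups of compound 3. It carries 3-chlorophenyl in place of 2-methylphenyl on an aromatic carbon, next to the ring nitrogen (3-chlorophenyl in place of 2-methylphenyl on an aromatic carbon).

For the measured compounds named here, no measured pair differs in one place only, so the data give no direct measure of this change. The three measured compounds differ from one another in more than one place, yet compound 1 at 29900 nM and compound 2 at 20100 nM remain within the scatter of compound 3. On that limited evidence, no step beyond the scatter is expected in this assay. The expected size is a 1.2-fold lower number from compound 3 to compound 4 (0.09 log units; within the scatter), which would leave the two compounds indistinguishable.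

For compound 4 the estimated value is 15000 nM, with an expected range from 6000 nM to 35000 nM.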

Compound 4, half-maximal inhibitory concentration: 23000 nM
The estimate for compound 4 lay 1.5-fold (0.19 log units) below the measured number, and the stated range covers the measured number.
By their numbers in this assay, from the lowest: compounds 3, 2, 4 and 1 (each within the scatter of the next).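

In this assay, for the compounds shown here, the exchange of 2-methylphenyl for 3-chlorophenyl on the aromatic carbon next to the ring nitrogen gives a 1.2-fold higher number from compound 3 to compound 4 (0.09 log units; within the scatter) and is the first step that can be read at a single place. With the 5-chlorothiophen-2-yl and furan-3-yl groups held, this pair of phenyl groups cannot be told apart on this read-out, even though both the substituent and its location on the phenyl ring differ. Nothing available bears on an explanation of this result.

Because both features change together, the pair does not show what the substituent and its location on the phenyl ring each contribute, and 3-methylphenyl at this position with the other two groups held would separate the two. Going by these compounds, it also remains open whether a phenyl ring carrying an amine or a carboxylic acid at this position, rather than a methyl or chlorine substituent, would give a step beyond the scatter.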